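This account rests on a few compounds, and the source may have more. Where it says the series, first, only, none or still open, it means among the compounds named here.

For the measured compounds named here, compound 2 `CC(C)(C)OC(=O)N1C[C@@H](n2cc(-c3ccc4nc(N)sc4n3)nn2)C[C@H]1C(=O)Nc1ccc(Cl)c(C(F)(F)F)c1` is one of two compounds measured in a functional assay on K562/Adr cells (Homo sapiens) for inhibition, read by MTT assay, with a stated time of 48 h, tested at 30 uM; a lower number here means less inhibition, a higher number more inhibition at the concentration tested (going by the name of the read-out); in that assay compound 2 gives 27.4%, the lowest of the two numbers. The other is compound 1 `CC(C)(C)OC(=O)N1C[C@@H](n2cc(-c3ccc4c(N)n[nH]c4c3)nn2)C[C@H]1C(=O)Nc1ccc(Cl)c(C(F)(F)F)c1`, which in this assay gives 37.1%; the step of a number 9.7 percentage points lower from compound 1 to compound 2 (within the scatter) lies within the scatter, so the two cannot be ordered. Compound 3 `CC(C)(C)OC(=O)N1C[C@@H](n2cc(-c3ccc4nc(N)sc4n3)nn2)C[C@H]1C(=O)Nc1ccc(Br)cc1` has not yet been measured in this assay. It differs from compound 2 in one place: 4-bromophenyl in place of 4-chloro-3-(trifluoromethyl)phenyl on an amide-type nitrogen. Going by the values given here, no measured step touches this part of the molecule; the only step at hand, a number 9.7 percentage points lower from compound 1 to compound 2 (within the scatter), concerns a different group and was itself within the scatter. With nothing to lean on, the expected step of a number 2.4 percentage points lower from compound 2 to compound 3 (within the scatter) is none beyond the scatter, and the range must be wide. Compound 3 is therefore estimated to give 25% in this assay, expected between 5% and 50%.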

Compound 3, a percentage reported as inhibition, at one concentration (the size of the read-out at that concentration, not a potency): 31.7%
Estimate against measurement, compound 3: 6.7 percentage points below; the measured number falls inside the stated range.
By their numbers in this assay, from the lowest: compounds 2, 3 and 1 (each within the scatter of the next).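

In this assay, for the compounds shown here, the change at the amide-type nitrogen from 4-chloro-3-(trifluoromethyl)phenyl to 4-bromophenyl gives a number 4.3 percentage points higher from compound 2 to compound 3 (within the scatter) and is the first reading at this position. The group on that nitrogen can thus go from 11 heavy atoms to 7, losing the trifluoromethyl group and exchanging chlorine for bromine, with no step beyond the scatter in this pair. No measurement available here offers an explanation for this result.

The compounds shown leave open whether a group without an aromatic ring, such as cyclohexyl, or a phenyl carrying a carboxylic acid or an amine, would give a number beyond the scatter on this nitrogen. They also leave open whether 4-bromophenyl would read the same on the core of compound 1.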